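The source may hold more compounds than are shown below. What is called first, only, known or untested is meant among the compounds shown, and "the series" means these compounds.

Measured compounds:
compound 1, `CC(=O)Nc1ccc(CN2CCC=C(CCC(=O)NO)C2=O)cc1`, "not determined" (no result reported) in a functional assay on ACHN cells (Homo sapiens) for inhibition, read by sulforhodamine B assay; on this read-out lower numbers stand for stronger inhibition of growth and higher numbers for weaker inhibition of growth
compound 2, `Cc1ccc(S(=O)(=O)Nc2ccc(CN3CCC=C(CCC(=O)NO)C3=O)cc2)cc1`, 370 nM

Compound 1 carries the shared core with an acetamido group on its outer aromatic ring. In this assay compound 1 gives "not determined" (no result reported), so no number stands for it; its position among the measured values is therefore unknown. Among the compounds with values here, compound 2, `Cc1ccc(S(=O)(=O)Nc2ccc(CN3CCC=C(CCC(=O)NO)C3=O)cc2)cc1`, is the only compound with a result: in this assay compound 2 gives 370 nM. Within the data shown here, since compound 1 and compound 2 differ in more than one place, no single step between them is available, and compound 2 can serve only as a loose point of reference for the potency this series reaches.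

Compound 3, `O=C(CCC1=CCCN(Cc2ccc([N+](=O)[O-])cc2)C1=O)NO`, is not yet measured. It differs from compound 1 as follows: nitro in place of acetamido on an aromatic carbon. Among the measured compounds shown here, with no number for compound 1, no step can be computed; the change is expected to shift growth inhibition only modestly, in either direction, likely within the usual scatter of this assay. Compound 3 is estimated to give 600 nM, in the range from 150 nM to 2500 nM.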

Compound 3, concentration for 50% growth inhibition: 5210 nM
The estimate for compound 3 lay 8.7-fold (0.94 log units) below the measured number; the measured number lies above the stated range.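

In this assay compound 3 gives 5210 nM, while compound 1 gives "not determined" (no result reported), so no step can be read between compound 1 and compound 3. The compounds shown leave open what replacing acetamido with nitro does to growth inhibition. No available evidence bears on the result for compound 3.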